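The source may report more compounds than this note shows. Statements on the series, on what has been measured and on what is new or still open speak of the compounds shown alone.

In a functional assay on UACC-62 cells (Homo sapiens) for antiproliferative activity, read by sulforhodamine B assay, with a stated time of 48 h (on this read-out lower numbers stand for stronger inhibition of growth and higher numbers for weaker inhibition of growth), compound 1 `COc1ccc(OC)c(/C=C/c2nnc(Nc3ccc(Cl)cc3)o2)c1` gives > 100000 nM, which is a limit of the assay and not a measured number. Compound 2 `COc1ccc(OC)c(/C=C/C(=O)N/N=C/c2ccc(Cl)cc2)c1` gives in this assay > 100000 nM, again a limit rather than a number. Both results therefore sit at the same place: the limit of > 100000 nM in this assay, at which 2 of the 2 values shown sit. Compound 2 thus stands at the limit, with no measured growth inhibition from which a direction could be read. Compound 3 `COc1ccc(OC)c(/C=C/C(=O)N/N=C/c2ccccc2)c1` differs from compound 2 in one place: hydrogen in place of chloro on an aromatic carbon. Going by the values given here, nothing among the measured compounds shows such a change moving a value off the limit, so the expected step in this assay is a number no higher from compound 2 to compound 3 (the limit leaves the size open), meaning no change beyond the usual scatter. Compound 3 is therefore estimated to give 100000 nM in this assay, within a range from 50000 nM to 200000 nM, and most likely the assay will again report only a limit.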

Compound 3, concentration for total growth inhibition: 75800 nM
For compound 3 the middle estimate is 1.3-fold (0.12 log units) above the measured one; low and high end bracket the measured number.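

With 4-chlorophenyl changed to phenyl, the series gains its first real number in this assay: compound 3 gives 75800 nM, which is a measured value and not a limit. The change amounts to an at least 1.3-fold lower number from compound 2 to compound 3 (0.12 log units; that floor lies within the scatter), so a chloro at this position is not needed for a measurable value, but the step cannot be said to go beyond normal repeat variation. Going by these compounds, its true size stays open because compound 2 gives only a limit: the limit of > 100000 nM in this assay, at which 2 of the 3 values shown sit.

The compounds shown leave open whether a different group at this position, such as an amine or a carboxylic acid, would move the number further in either direction. They also leave open whether the same change from chloro to hydrogen on the core of compound 1 would bring that compound off its limit.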